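Lengthening the chain on compound 2

A few compounds are considered here, and "the series" means these few. Any claim that something is new, unique, unknown or untested is made for them only; others in the source may bear on it.

Measured so far in a functional assay on A549 cells (Homo sapiens) for antiproliferative activity, read by sulforhodamine B assay, with a stated time of 48 h; on this read-out lower numbers stand for stronger inhibition of growth and higher numbers for weaker inhibition of growth:
- compound 1 `CC(C)CCc1c(OCCCCCC(=O)NO)ccc2ccc(=O)oc12`: 870 nM
- compound 2 `CC(C)CCc1c(OCCCCC(=O)NO)ccc2ccc(=O)oc12`: 2760 nM

Of these two numbers, compound 2 has the higher, at 2760 nM, so it inhibits growth less strongly than compound 1. The next compound to be tested is compound 3 `CC(C)CCc1c(OCCCCCCC(=O)NO)ccc2ccc(=O)oc12`. It differs from compound 2 by 2-(hydroxycarbamoyl)ethyl in place of hydroxycarbamoyl on a saturated chain carbon, four bonds along the chain from an oxygen on an aromatic ring. In words, 2-(hydroxycarbamoyl)ethyl stands in place of hydroxycarbamoyl on a saturated chain carbon, four bonds along the chain from an oxygen on an aromatic ring.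

Among the compounds with values here, only one measured step bears on this change: a 3.2-fold higher number from compound 1 to compound 2 (0.50 log units; beyond the scatter). It is modest but beyond the scatter, and the shorter group gives the weaker result. Compound 3 extends the chain past the length found in compound 1, so a lower number than that of compound 2 is expected. Two compounds cannot show whether the gain continues at this greater length, so the range stays wide. In this assay the expected change is a 4.6-fold lower number from compound 2 to compound 3 (0.66 log units; beyond the scatter). Compound 3 is estimated at 600 nM, with an expected range of 220 nM to 1600 nM.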

Compound 3, concentration for 50% growth inhibition: 660 nM
Compound 3: the middle estimate sits 1.1-fold (0.04 log units) below what was measured; the range from low to high includes it.
By their numbers in this assay, from the lowest: compounds 3 and 1 (each within the scatter of the next); then compound 2.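

In this assay, the chain can do better than the shortest one shown, and the new compound confirms this with a 4.2-fold lower number from compound 2 to compound 3 (0.62 log units; beyond the scatter) for 2-(hydroxycarbamoyl)ethyl in place of hydroxycarbamoyl. What the earlier pair could not show is how the number behaves once the chain passes the length in compound 1: that comparison gives a 1.3-fold lower number from compound 1 to compound 3 (0.12 log units; within the scatter) and so the two longer chains cannot be told apart in this assay, which means the clear difference so far lies only between the shortest chain and the other two. Nothing among the data explains why chain length matters at this position.

Three chain lengths cannot say whether the numbers stay level, rise or fall with a longer chain still, so the pattern holds only for these compounds. From the compounds shown here alone, it also remains open how this position responds when the hydroxycarbamoyl end of the chain gives way to a different group, such as a carboxylic acid or an amine, with the chain and the shared core kept the same.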